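A side chain swap on a well-tolerated compound

The source may hold more compounds than are shown below. What is called first, only, known or untested is meant among the compounds shown, and "the series" means these compounds.

Compound 1 (`COc1ccc(-c2nc(C(F)(F)S(=O)(=O)c3cccc(Cl)c3)nc3ccsc23)cn1`) and compound 2 (`COc1ccc(-c2nc(COc3cccc(Cl)c3)nc3ccsc23)cn1`) were both measured in an ADME assay on cells (Homo sapiens) for cytotoxicity, read by resazurin assay, with a stated time of 5 days; a higher number here means that more compound is tolerated, a lower number that less compound is tolerated. Compound 1 gives > 50000 nM as a limit of the assay, not a number. Compound 2 gives > 50000 nM as a limit too. Compound 2 therefore stands at the limit of > 50000 nM in this assay, at which 2 of the 2 values shown sit, and has no exact value. Compound 3 (`COc1ccc(-c2nc(CSCc3cccc(Cl)c3)nc3ccsc23)cn1`) carries (3-chlorobenzyl)sulfanyl in place of 3-chlorophenoxy on a saturated chain carbon bound to an aromatic carbon. Among the compounds with values here, no measured step offers a guide, so at most a slight drop within the usual scatter is expected, the estimated at least 1.2-fold lower number from compound 2 to compound 3 (0.09 log units; that floor lies within the scatter) in this assay. For compound 3 the estimated value is 40000 nM with an expected range from 15000 nM to 50000 nM in this measurement.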

Compound 3, half-maximal cytotoxic concentration: > 50000 nM
Compound 3: a limit, no number (the forecaster's own chance of this, stated with the estimate: 65%); middle value at least 1.2-fold (0.09 log units) from the limit.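

Compound 2 and compound 3 both give a limit and not a number in this assay and so no step between them can be read: the limit of > 50000 nM in this assay, at which 3 of the 3 values shown sit.

The compounds shown leave open at what concentration any of them becomes toxic to these cells, and whether the side chain swap changes that concentration at all.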